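Aryl thiazole cinnamamides: the para substituent step

The source may report more compounds than this note shows. Statements on the series, on what has been measured and on what is new or still open speak of the compounds shown alone.

In an ADME assay on HEK293 cells (Homo sapiens) for inhibition, read by MTT assay, with a stated time of 96 h (on this read-out higher numbers stand for weaker inhibition and lower numbers for stronger inhibition), compound 1 `Cc1cc(C)c(-c2csc(NC(=O)/C=C/c3ccc(C(C)(C)C)cc3)n2)c(C)c1` reaches only the limit of > 90000 nM. Compound 2 `Cc1cc(C)c(-c2csc(NC(=O)/C=C/c3ccc(C(F)(F)F)cc3)n2)c(C)c1` likewise gives only the limit > 90000 nM in this assay. The step that the two limits leave unreadable from compound 1 to compound 2 therefore cannot be read, since both values sit at the limit of > 90000 nM in this assay, at which 2 of the 2 values shown sit. Compound 3 `Cc1cc(C)c(-c2csc(NC(=O)/C=C/c3ccc(C4CC4)cc3)n2)c(C)c1` differs from compound 2 by cyclopropyl in place of trifluoromethyl on an aromatic carbon. Going by the values given here, no measured step bears on this change; with compound 2 at a limit, no step beyond the scatter is expected in this assay, and compound 3 is expected to remain at the limit as well. For compound 3 the estimate is 150000 nM, between 60000 nM and 500000 nM, an expected step that the limit leaves unreadable from compound 2 to compound 3.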

Compound 3, half-maximal inhibitory concentration: > 90000 nM
Compound 3: a limit, no number; the forecaster's own chance of this, stated with the estimate: 85%; the middle value lies beyond the limit too.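

Compound 3, like compound 1 and compound 2, gives only a limit in this assay, so no new step can be read among them: the limit of > 90000 nM in this assay, at which 3 of the 3 values shown sit.

The compounds shown leave open whether exchanging the group on the aromatic carbon changes inhibition at all.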